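Swapping the terminal amine on the propoxy chain

The source may report more compounds than this note shows. Statements on the series, on what has been measured and on what is new or still open speak of the compounds shown alone.

This account follows the shared core of compound 2 `COc1cc2c(Nc3ccc(C#N)cc3)ncnc2cc1OCCCN1CCCC1` as its chain amine is altered. In a functional assay on MCF7 cells (Homo sapiens) for antiproliferative activity, read by MTT assay, with a stated time of 72 h (on this read-out higher numbers stand for weaker inhibition and lower numbers for stronger inhibition), compound 2 gives 16200 nM, the lowest of the two numbers recorded. Compound 3 `COc1cc2c(Nc3ccc(C#N)cc3)ncnc2cc1OCCCN1CCCCC1` gives 35100 nM in this assay. Compound 1 `COc1cc2c(Nc3ccc(C#N)cc3)ncnc2cc1OCCCN(C)Cc1ccccc1` reaches only a limit of this assay, > 100000 nM. The step of a 2.2-fold higher number from compound 2 to compound 3 (0.34 log units; beyond the scatter) is the one that bears directly on the new compound, since it also exchanges the five-membered amine for a six-membered one. The steps of an at least 6.1-fold lower number from compound 1 to compound 2 (0.79 log units; beyond the scatter) and an at least 2.8-fold lower number from compound 1 to compound 3 (0.45 log units; beyond the scatter) show that the amine choice moves the numbers by at least a modest amount. Compound 4 `COc1cc2c(Nc3ccc(C#N)cc3)ncnc2cc1OCCCN1CCC(N(C)C)CC1` carries the change (4-(dimethylamino)piperidin-1-yl in place of pyrrolidin-1-yl on a saturated chain carbon, three bonds along the chain from an oxygen on an aromatic ring). For the measured compounds named here, since the six-membered ring alone cost a modest amount, and no measured pair speaks to the added dimethylamino group, a modest rise in this assay is expected, a 1.7-fold higher number from compound 2 to compound 4 (0.24 log units; within the scatter). Compound 4 is therefore estimated at 28000 nM, within 9000 nM to 85000 nM.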

Compound 4, half-maximal inhibitory concentration: 31000 nM
The estimate for compound 4 lay 1.1-fold (0.04 log units) below the measured number; low and high end bracket the measured number.
By their numbers in this assay, from the lowest: compounds 2, 4 and 3 (each within the scatter of the next, the first and the last beyond it). At a limit, above all of these: compound 1.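

In this assay, putting dimethylamino in place of hydrogen on a saturated ring carbon gives a step that stays within the scatter, a 1.1-fold lower number from compound 3 to compound 4 (0.05 log units; within the scatter), so this added group shows no measurable effect on the number. The full exchange of pyrrolidin-1-yl for 4-(dimethylamino)piperidin-1-yl also stays within the scatter, a 1.9-fold higher number from compound 2 to compound 4 (0.28 log units; within the scatter), so at this place on the chain the new amine cannot be told apart from either compound it was compared with. Replacing benzyl(methyl)amino gives an at least 3.2-fold lower number from compound 1 to compound 4 (0.50 log units; beyond the scatter), a step read against a limit and not against a number: the limit of > 100000 nM in this assay, at which 1 of the 4 values shown sits.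

From the compounds shown here alone, what a morpholin-4-yl or 4-methylpiperazin-1-yl group would do at this place remains open. So does the effect of a butoxy chain in place of the propoxy chain on these amines.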